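One Fluoro Removed: From Compound 1 to Compound 4

This account rests on a few compounds, and the source may have more. Where it says the series, first, only, none or still open, it means among the compounds named here.

Compound 1, `O=C1O[C@]2(CC[C@H](CNc3cnn(-c4ccccc4F)c3)CC2)CN1c1cccnc1F`, is one of three compounds examined in a functional assay for antagonist activity at Neuropeptide Y receptor type 5 (Homo sapiens); a lower number here means a stronger inhibitor, a higher number a weaker inhibitor. In this assay compound 1 gives 0.1 nM. Compound 2, `O=C1O[C@]2(CC[C@H](CNc3ccc(-c4cc(F)cc(F)c4)nn3)CC2)CN1c1cccnn1`, gives 0.1 nM, level with compound 1 at the digits shown. Compound 3, `O=C1O[C@]2(CC[C@H](CNc3ccc(OC4CCC4)cn3)CC2)CN1c1ccccn1`, gives 0.159 nM; the gap between compound 3 and compound 1 lies within the usual scatter, so all three compounds sit together at the same level, and none can be called stronger than another.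

Compound 4, `O=C1O[C@]2(CC[C@H](CNc3cnn(-c4ccccc4F)c3)CC2)CN1c1cccnc1`, has not yet been measured. It differs from compound 1 in a single place: hydrogen in place of fluoro on an aromatic carbon. Read one bond further out, the 2-fluoropyridin-3-yl group of compound 1 becomes pyridin-3-yl in compound 4. Within the data shown here, no pair of measured compounds isolates this particular change, so the expectation rests on compound 1 itself and on the observation that compound 2 and compound 3, which differ from compound 1 in several places, still give numbers at the same level.

The step of a 1.6-fold higher number from compound 1 to compound 4 (0.20 log units; within the scatter) is expected to be small, either none beyond the scatter or a slight shift towards a higher number. Compound 4 is therefore estimated to give about 0.16 nM, within a range from 0.05 nM to 0.5 nM.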

Compound 4, inhibition constant: 0.1 nM
Estimate against measurement, compound 4: 1.6-fold (0.20 log units) above, within the range that was stated.
By their numbers in this assay, from the lowest: compounds 1, 2, 4 and 3 (each within the scatter of the next).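

In this assay, replacing fluoro with hydrogen turns the 2-fluoropyridin-3-yl group into pyridin-3-yl, and the step reads no change at the digits printed from compound 1 to compound 4 (within the scatter). The three earlier compounds differed from one another in several places, so they could not show what this one atom contributes; this pair isolates it and shows that, on this compound, the fluoro on the aromatic carbon next to the ring nitrogen is not needed for a value at this level. The data offer no measurement that explains why the swap leaves the number in place.

The compounds shown test only two atoms at this place, fluoro and hydrogen, so they leave open whether a larger group, such as chloro, methyl, methoxy or an amine, would keep the number at this level or move it clearly. They also hold this swap on one compound only, so whether hydrogen and fluoro stay level when the rest of the molecule changes remains an open question.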